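Azo anilines: difluorophenyl in place of phenyl on compound 2

This account rests on a few compounds, and the source may have more. Where it says the series, first, only, none or still open, it means among the compounds named here.

Measured compounds:
- Compound 1 `CN(C)CCCNc1ccc(/N=N/c2ccc([N+](=O)[O-])cc2)cc1`: in an ADME assay on BHK-21 cells (Mesocricetus auratus) for cytotoxicity, read by MTT assay, with a stated time of 96 h (on this read-out lower numbers stand for higher toxicity in this test and higher numbers for lower toxicity in this test), compound 1 gives > 100000 nM, a limit of the assay.
- Compound 2 `c1ccc(/N=N/c2ccc(NC[C@@H]3CCCN4CCCC[C@H]34)c3c2CCCC3)cc1`: in this assay compound 2 gives > 100000 nM, a limit of the assay.
- Compound 3 `CN(C)CCCNc1ccc(/N=N/c2ccccc2)cc1`: in this assay compound 3 gives 31000 nM.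

Compound 2 therefore stands at a limit, not at a number; the same holds for compound 1, so that (the limit of > 100000 nM in this assay, at which 2 of the 3 values shown sit). Among the compounds with values here, compound 3 is the one compound of the three with a read number.

Within the data shown here, the only measured step that differs in one place is an at least 3.2-fold lower number from compound 1 to compound 3 (0.50 log units; beyond the scatter); it concerns a nitro group, not the change taken here, and so bears on the present step only by showing that a single change on the aryl attached to the double-bonded nitrogen can move the number beyond the scatter.

Compound 4 `Fc1ccc(/N=N/c2ccc(NC[C@@H]3CCCN4CCCC[C@H]34)c3c2CCCC3)c(F)c1` differs from compound 2 by 2,4-difluorophenyl in place of phenyl on a double-bonded nitrogen. Among the measured compounds shown here, no measured compound carries a fluorinated aryl, so nothing sets a size for this step. In this assay the expectation for compound 4 is a number no higher from compound 2 to compound 4 (the limit leaves the size open), that is, no step beyond the scatter. Compound 4 is accordingly expected to give about 100000 nM, within 30000 nM to 300000 nM, most likely again only a limit.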

Compound 4, half-maximal cytotoxic concentration: 9000 nM
Compound 4: middle estimate off by 11-fold (1.05 log units), on the high side; the whole stated range lies above it.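

In this assay the exchange of phenyl for 2,4-difluorophenyl on a double-bonded nitrogen gives an at least 11-fold lower number from compound 2 to compound 4 (1.04 log units; beyond the scatter), so this position on the core of compound 2 does respond to fluorine on the aryl, and the change moves toward higher toxicity in this test. The earlier step on this aryl, an at least 3.2-fold lower number from compound 1 to compound 3 (0.50 log units; beyond the scatter), concerned a nitro group on another core and said nothing about fluorine or about the core of compound 2. The true size of the new step stays unknown because its starting point is only a limit: the limit of > 100000 nM in this assay, at which 2 of the 4 values shown sit.

Open, going by these compounds, is whether a single fluorine on the phenyl ring gives a step of the same kind, or whether a dichlorophenyl group in place of the 2,4-difluorophenyl does so. Also open, on these data alone, is whether 2,4-difluorophenyl on the core of compound 3, with its dimethylaminopropyl chain, lowers a read number, which would give this change a size that is not bounded by a limit.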